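The compounds below may be only part of what the source reports. "The series", "measured", "known", "first", "only" and "open" are said of these compounds alone.

Compound 2, with the structure `CCN(Cc1ccc(F)cc1)c1cccc(C(=O)N2CCc3ccc(OS(N)(=O)=O)cc3C2)c1`, stands at the bottom of the three measured values in an assay on HEK293 cells for inhibition of Steryl-sulfatase (Homo sapiens), tested at 0.1 uM; on this read-out higher numbers stand for a stronger effect at the one concentration tested and lower numbers for a weaker effect: compound 2 gives 10.9%. Compound 3, whose structure is `CCCN(CCC)c1ccc(C(=O)N2CCc3ccc(OS(N)(=O)=O)cc3C2)cc1`, gives 36.6% in this assay, and compound 1, whose structure is `CCN(Cc1ccc(F)cc1)c1ccc(C(=O)N2CCc3ccc(OS(N)(=O)=O)cc3C2)cc1`, gives 69.1%. Compound 1 and compound 2 carry the same groups but arranged differently on the shared core, and their values lie far apart.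

Compound 4, with the structure `CCCN(Cc1ccccc1)c1cccc(C(=O)N2CCc3ccc(OS(N)(=O)=O)cc3C2)c1`, is the next compound to be measured. It differs from compound 2 by one change: benzyl(propyl)amino in place of ethyl(4-fluorobenzyl)amino on an aromatic carbon. Among the compounds with values here, this change keeps a benzyl-type substituent on the amine nitrogen, so the only measured step that speaks to it does so indirectly: the step from compound 1 to compound 3 removed the benzyl group entirely and produced a number 32.5 percentage points lower from compound 1 to compound 3 (beyond the scatter). Within the data shown here, no measured step shows what trading the fluorine and lengthening the alkyl chain does on its own, and compound 2 itself sits near the low end of what this assay can report.

Compound 4 is therefore expected to show a number 4.1 percentage points higher from compound 2 to compound 4 (within the scatter), a small shift that stays within the scatter, giving an estimated value of 15% with a range from 3% to 35%.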

Compound 4, a percentage reported as inhibition, at one concentration (the size of the read-out at that concentration, not a potency): 23.1%
Estimate against measurement, compound 4: 8.1 percentage points below; the range from low to high includes it.
By their numbers in this assay, from the lowest: compound 2; then compound 4; then compound 3; then compound 1.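

In this assay, the step of a number 12.2 percentage points higher from compound 2 to compound 4 (beyond the scatter) shows that the result at this position, an aromatic carbon meta to a large group, depends on more than whether the amine carries a benzyl-type substituent. The earlier step of a number 32.5 percentage points lower from compound 1 to compound 3 (beyond the scatter) removed the aromatic ring from the amine substituent altogether, whereas here ethyl(4-fluorobenzyl)amino and benzyl(propyl)amino have the same number of heavy atoms and each keeps one six-membered aromatic ring, yet the number still moves beyond the scatter. The change combines the loss of the fluorine with the move from ethyl to propyl, and no information on the cause of the rise is available here.

The compounds shown leave open how the step divides between the fluorine and the chain, which a compound pairing the ethyl chain with an unsubstituted benzyl group or the propyl chain with a 4-fluorobenzyl group could separate. They also leave open whether a longer chain such as butyl, or a chlorine on the benzyl ring, would carry the number further at this position.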